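Aryl swap on a piperazine in an adenosine receptor assay

A few compounds are considered here, and "the series" means these few. Any claim that something is new, unique, unknown or untested is made for them only; others in the source may bear on it.

Compound 1 `Nc1scc(CN2CCN(c3cc(Cl)cc(Cl)c3)CC2)c1C(=O)c1ccc(Cl)cc1` and compound 2 `COc1ccc(N2CCN(Cc3csc(N)c3C(=O)c3ccc(Cl)cc3)CC2)cc1` share a core and differ only in the aryl group on the ring nitrogen. In a functional assay on CHO cells with adenosine receptor A1 (Homo sapiens) as the target, read by cAMP accumulation and immunoassay, with a stated time of 6 min, tested at 0.01 uM (a higher number here means a weaker effect of the compound at the concentration tested, a lower number a stronger effect), compound 1 gives -1%, and compound 2 gives -1.2%. The step of a number 0.2 percentage points lower from compound 1 to compound 2 (within the scatter) is within the scatter, so the two numbers cannot be told apart, and both lie near zero. Compound 3 `Nc1scc(CN2CCN(c3ccc(Cl)c(C(F)(F)F)c3)CC2)c1C(=O)c1ccc(Cl)cc1` has not yet been measured; it carries 4-chloro-3-(trifluoromethyl)phenyl in place of 4-methoxyphenyl on an amine nitrogen in a ring. For the measured compounds named here, the only measured step that bears on this position, from compound 1 to compound 2, was within the scatter, so no step beyond the scatter is expected in this assay here either. The expected step of a number 0.2 percentage points higher from compound 2 to compound 3 (within the scatter) is therefore estimated to be negligible. Compound 3 is expected to give about -1%, with a range from -12% to 10%.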

Compound 3, a percentage reported as activity, at one concentration (the size of the read-out at that concentration, not a potency): -2.5%
For compound 3 the middle estimate is 1.5 percentage points above the measured one, and the stated range covers the measured number.
By their numbers in this assay, from the lowest: compounds 3, 2 and 1 (each within the scatter of the next).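

In this assay, putting 4-chloro-3-(trifluoromethyl)phenyl on the ring nitrogen gives a number 1.3 percentage points lower from compound 2 to compound 3 (within the scatter), and set against the 3,5-dichlorophenyl group it gives a number 1.5 percentage points lower from compound 1 to compound 3 (within the scatter). Three differently substituted phenyl groups, now including one that carries fluorine, therefore cannot be told apart at this position, and all three numbers lie near zero at the single concentration tested. No supporting data speak to why these numbers match.

Still open, on these data alone, is whether a different kind of group on this nitrogen, such as a pyridine ring or a benzyl group, would move the number beyond the scatter. A single concentration also leaves open whether these compounds would show an effect at higher concentrations.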